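Swapping Trifluoromethyl for Fluoro in Three Close Analogues

The source may report more compounds than this note shows. Statements on the series, on what has been measured and on what is new or still open speak of the compounds shown alone.

Compound 1 `Cc1cccc(Cn2c(CN3CCN(C(=O)c4ccc([N+](=O)[O-])cc4)CC3)nc3ccccc32)c1` gives 24.3% in an assay on isolated protein for inhibition of aldehyde dehydrogenase 1A1 (Homo sapiens), read by spectrophotometry, tested at 10 uM; a lower number here means less inhibition, a higher number more inhibition at the concentration tested (going by the name of the read-out).
Compound 2 `Cc1cccc(Cn2c(CN3CCN(C(=O)c4ccc(C(F)(F)F)cc4)CC3)nc3ccccc32)c1` gives 22.9% in this assay.
Compound 3 `O=C(C1CC1)N1CCN(Cc2nc3ccccc3n2Cc2cccc(F)c2)CC1` gives 27.2% in this assay.

Among these three numbers, compound 2 has the lowest reading, but its nearest neighbour is compound 1, and the two lie within the scatter of each other; the further neighbour, compound 3, also lies within the scatter of compound 2. So none of the three can be called weaker or stronger than another on this evidence.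

The compound still to be measured is compound 4 `Cc1cccc(Cn2c(CN3CCN(C(=O)c4ccc(F)cc4)CC3)nc3ccccc32)c1`. It differs from compound 2 by fluoro in place of trifluoromethyl on an aromatic carbon.

Going by the values given here, only one measured step touches the same aromatic carbon: a number 1.4 percentage points lower from compound 1 to compound 2 (within the scatter), in which trifluoromethyl replaced nitro and the reading barely moved. Among the compounds with values here, no measured step exchanges trifluoromethyl for fluoro, so the bearing of that step is indirect. Given that the one substituent change already seen at this position stayed within the scatter, compound 4 is expected to show a step of a number 0.1 percentage points higher from compound 2 to compound 4 (within the scatter), that is, no change beyond the scatter. Compound 4 is therefore estimated at 23%, with a range from 12% to 34%.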

Compound 4, a percentage reported as inhibition, at one concentration (the size of the read-out at that concentration, not a potency): 27.1%
Estimate against measurement, compound 4: 4.1 percentage points below, and the stated range covers the measured number.
By their numbers in this assay, from the lowest: compounds 2, 1, 4 and 3 (each within the scatter of the next).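

In this assay, fluoro in place of trifluoromethyl gives a number 4.2 percentage points higher from compound 2 to compound 4 (within the scatter) and fluoro in place of nitro gives a number 2.8 percentage points higher from compound 1 to compound 4 (within the scatter), so neither exchange moves the reading beyond the scatter. Going by these compounds alone, the earlier compounds showed only one exchange at this aromatic carbon, whereas three substituents can now be compared there, and compound 1, compound 2 and compound 4 all lie within the scatter of one another, even though fluoro has one heavy atom where trifluoromethyl has four. No measured evidence is at hand that would account for this flat reading.

From the compounds shown here alone, it remains open whether a group of another kind on this carbon, such as an amine, a carboxylic acid or a longer alkoxy chain, would carry the reading beyond the scatter. Also open, going by these compounds, are whether fluoro in place of trifluoromethyl would read the same on a different core, and whether compound 1, compound 2 and compound 4 would also read alike at other concentrations, which a reading at a single concentration cannot tell.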